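Ester for nitrile at the chain end of compound 1

The source may hold more compounds than are shown below. What is called first, only, known or untested is meant among the compounds shown, and "the series" means these compounds.

Compound 1 `C=CCc1cc(C(C)=O)c(O)cc1OCCCCCCCC#N` and compound 2 `CCc1cc(C(C)=O)c(O)cc1OCCCC(C)(C)c1nnn[nH]1` share a core. In an assay on isolated protein for inhibition of leukotriene B4 receptor 1 (Homo sapiens), tested at 10 uM (on this read-out lower numbers stand for less inhibition and higher numbers for more inhibition at the one concentration tested (going by the name of the read-out)), compound 1 gives 88%, the lower of the two numbers measured, and compound 2 gives 100%, a gap beyond the scatter. Compound 3 `C=CCc1cc(C(C)=O)c(O)cc1OCCCCCC(=O)OC` differs from compound 1 in one place: methoxycarbonyl in place of 2-cyanoethyl on a saturated chain carbon, five bonds along the chain from an oxygen on an aromatic ring. Among the measured compounds shown here, no step between measured compounds isolates this change, so there is nothing measured to lean on. The step from compound 1 to compound 3 is expected to be small, within the scatter, a number 3 percentage points lower from compound 1 to compound 3 (within the scatter). Compound 3 is therefore expected to give 85%, in a range of 65% to 98%.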

Compound 3, a percentage reported as inhibition, at one concentration (the size of the read-out at that concentration, not a potency): 106%
Compound 3: the middle estimate sits 21 percentage points below what was measured; the whole stated range lies below it.
By their numbers in this assay, from the lowest: compound 1; then compounds 2 and 3 (each within the scatter of the next).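

In this assay the exchange of 2-cyanoethyl for methoxycarbonyl on a saturated chain carbon, five bonds along the chain from an oxygen on an aromatic ring, comes with a number 18 percentage points higher from compound 1 to compound 3 (beyond the scatter) and so the read-out responds to what ends this chain. Among the compounds shown here, this is the first step that isolates a change at this position. Nothing measured here bears on the origin of the step. Still open, on these data alone, is how a carboxylic acid or an amine at the same chain end would read. Also open, as far as these compounds go, is whether a longer chain carrying the methyl ester keeps the step.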